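Dropping One Methoxy Group from a Weak Cytotoxic Quinazoline Amide

The source may report more compounds than this note shows. Statements on the series, on what has been measured and on what is new or still open speak of the compounds shown alone.

Compound 1 `COc1cc(/C=C/C(=O)Nc2cc3c(Nc4ccc(F)c(Cl)c4)ncnc3cc2O[C@H]2CCOC2)cc(OC)c1` and compound 2 `COc1cc2ncnc(Nc3ccc(F)c(Cl)c3)c2cc1NC(=O)/C=C/c1ccccc1[N+](=O)[O-]` were both tested in a functional assay on PC-3 cells (Homo sapiens) for cytotoxicity, read by MTT assay, with a stated time of 72 h; a higher number here means a weaker inhibitor, a lower number a stronger inhibitor. In this assay compound 1 gives 25600 nM and compound 2 gives 14300 nM, two values that lie within the usual scatter of each other, so neither can be called the stronger. Compound 3 `COc1ccc(/C=C/C(=O)Nc2cc3c(Nc4ccc(F)c(Cl)c4)ncnc3cc2O[C@H]2CCOC2)cc1` has not yet been measured. It differs from compound 1 in a single place (4-methoxyphenyl in place of 3,5-dimethoxyphenyl on a double-bonded chain carbon bound to a double-bonded chain carbon). Within the data shown here, no measured pair shows this change, so the step is expected to be small, no larger than the scatter a 1.3-fold lower number from compound 1 to compound 3 (0.11 log units; within the scatter). Compound 3 is therefore expected to give 20000 nM, with a likely range from 8000 nM to 50000 nM.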

Compound 3, half-maximal inhibitory concentration: 2240 nM
Compound 3: the middle estimate sits 8.9-fold (0.95 log units) above what was measured; the measured number lies below the stated range.
By their numbers in this assay, from the lowest: compound 3; then compounds 2 and 1 (each within the scatter of the next).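

In this assay the 4-methoxyphenyl group in place of 3,5-dimethoxyphenyl gives an 11-fold lower number from compound 1 to compound 3 (1.06 log units; beyond the scatter), so the cell read-out is sensitive to what this end of the chain carries, even with the rest of the molecule unchanged. The swap alters the number of methoxy groups and their placement together, so this one step cannot separate the two. Nothing shown explains the size of the step. Still open, from the compounds shown here alone, is how plain phenyl would compare, and whether an amine or a carboxylic acid in place of the methoxy group would keep this lower number.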